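Cyclic group swap on the chlorinated series

This account rests on a few compounds, and the source may have more. Where it says the series, first, only, none or still open, it means among the compounds named here.

Measured so far in a physicochemical assay for lipophilicity, using the shake flask method, measured as octanol-water partition, at pH 7.4 (a higher number here means a more lipophilic compound, a lower number a more polar compound), for this series:
- compound 1 `CC(=O)N[C@@H]1CCC[C@H](C(=O)Nc2cc(-c3cnc(C)n3C(C)C)ccn2)C1` gives 1.9
- compound 2 `CC(=O)N[C@@H]1CCC[C@H](C(=O)Nc2cc(-c3cnc4n3CCCC4)c(Cl)cn2)C1` gives 2.7

Compound 2 at 2.7 is the higher of the two readings, and compound 1 at 1.9 lies lower by more than the usual scatter. These two compounds differ in more than one place, so their gap cannot be assigned to any single change.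

Compound 3 `CC(=O)N[C@@H]1CCC[C@H](C(=O)Nc2cc(-c3cnc4n3CCC4)c(Cl)cn2)C1` has not yet been measured. It differs from compound 2 by one exchange a group of 8 heavy atoms (6 carbon, 2 nitrogen; one five-membered non-aromatic ring with 1 hetero atom, one five-membered aromatic ring with 2 hetero atoms) in place of a group of 9 heavy atoms (7 carbon, 2 nitrogen; one five-membered aromatic ring with 2 hetero atoms, one six-membered non-aromatic ring with 1 hetero atom), on an aromatic carbon ortho to a chloro group. The six-membered non-aromatic ring with 1 hetero atom gives way to a five-membered non-aromatic ring with 1 hetero atom.

Within the data shown here, no measured pair shows this exchange, so the expectation rests on the structural change alone, starting from compound 2 at 2.7 as the closest reference. A small downward step in this assay is expected, near the edge of the scatter. The estimated step is a number 0.30 log units lower from compound 2 to compound 3 (within the scatter) on this reading. Compound 3 is expected at 2.4 (2.1 to 2.7) in this estimate.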

Compound 3, distribution coefficient: 2.6
Beside the measured number, compound 3's estimate is 0.20 log units below it; low and high end bracket the measured number.
By their numbers in this assay, from the lowest: compound 1; then compounds 3 and 2 (each within the scatter of the next).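

On the aromatic carbon ortho to a chloro group and opposite the ring nitrogen, the series now has its first change that can be read on its own: replacing the six-membered non-aromatic ring with 1 hetero atom by a five-membered non-aromatic ring with 1 hetero atom gives a number 0.10 log units lower from compound 2 to compound 3 (within the scatter) in this assay. Among these compounds, at this position, then, this change in ring size, which removes one carbon and leaves the counts of hydrogen-bond donors and acceptors and the net charge as they were, produces no step that can be told from repeat measurement. The data at hand offer no measured basis for explaining this result.

Among the compounds shown here, whether the same exchange behaves alike without the chloro group stays open, since the one compound lacking that group, compound 1, also carries a different group at this position. Also open, as far as these compounds go, is whether a seven-membered non-aromatic ring, or an added amine or carboxylic acid on the ring at this position, would give a step beyond the scatter in this assay on the shared core.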